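Phenyl for propyl on the sulfur chain, two pairs

The source may report more compounds than this note shows. Statements on the series, on what has been measured and on what is new or still open speak of the compounds shown alone.

Compound 3 `CCCCCSc1nc(Nc2ccccc2Cl)c2cn[nH]c2n1` and compound 2 `Clc1ccccc1Nc1nc(SCCc2ccccc2)nc2[nH]ncc12` share one core and differ in a single place, (phenyl in place of propyl on a saturated chain carbon, two bonds along the chain from a sulfur). In a functional assay on K562 cells (Homo sapiens) for antiproliferative activity, read by fluorescence, with a stated time of 3 days (on this read-out lower numbers stand for stronger inhibition and higher numbers for weaker inhibition), compound 3 gives 19900 nM, and in this assay compound 2 gives 19900 nM. Among the compounds with values here, the step of no change at the digits printed from compound 3 to compound 2 (within the scatter) is the one measured reading of this change. Compound 1 `CCCCCSc1nc(OC(=O)c2cc3ccccc3o2)c2cn[nH]c2n1` carries another core; how its core differs from that of compound 3 is not broken down here. In this assay compound 1 gives 19800 nM, a value within the scatter of those of compound 2 and compound 3. Compound 4 `O=C(Oc1nc(SCCc2ccccc2)nc2[nH]ncc12)c1cc2ccccc2o1` is not yet measured; it differs from compound 1 by phenyl in place of propyl on a saturated chain carbon, two bonds along the chain from a sulfur, the same change as that from compound 3 to compound 2 and at the same place. Within the data shown here, nothing among the measured compounds suggests the change reads differently on the core of compound 1. For compound 4 the expected step is a 1.0-fold higher number from compound 1 to compound 4 (0.00 log units; within the scatter), resting on no change at the digits printed from compound 3 to compound 2 (within the scatter). Compound 4 is therefore estimated at 20000 nM, with a likely range from 8000 nM to 50000 nM.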

Compound 4, half-maximal inhibitory concentration: 19800 nM
Estimate against measurement, compound 4: 1.0-fold (0.00 log units) above; the range from low to high includes it.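

In this assay the new pair gives no change at the digits printed from compound 1 to compound 4 (within the scatter) when phenyl replaces propyl on a saturated chain carbon, two bonds along the chain from a sulfur. Set beside the earlier pair, the change reads the same on both cores, with no gap beyond the scatter: the same change on two cores in this assay, no change at the digits printed (within the scatter) from compound 3 to compound 2 and no change at the digits printed (within the scatter) from compound 1 to compound 4, 1.0-fold (0.00 log units) apart, within the scatter of two such steps

This agreement is between two steps of no visible size, so it shows that the change leaves the number where it stands on these two cores, not that a step of real size would carry from one core to the other, and two cores say nothing about any others in the series.

Still open, on these data alone, is whether any group on the sulfur chain moves the number away from this level on either core, for instance a longer chain, an amine or a carboxylic acid in place of the phenyl. Also open, as far as these compounds go, is whether the two cores would part once such a group gave a step beyond the scatter.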